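Swapping an Ethoxy for Methylsulfanyl on a Shared Core

The source may hold more compounds than are shown below. What is called first, only, known or untested is meant among the compounds shown, and "the series" means these compounds.

Compound 1 `Cc1ccccc1CNc1ncnn1-c1cccc(Cl)c1Cl`, compound 2 `COc1ccccc1CNc1ncnn1-c1cccc(Cl)c1Cl` and compound 3 `CCOc1ccccc1CNc1ncnn1-c1cccc(Cl)c1Cl` share one core and differ only in a small group on the six-membered aromatic ring of carbon only. In a functional assay for antagonist activity at P2X purinoceptor 7 (Rattus norvegicus), read by FLIPR and calcium flux (on this read-out lower numbers stand for stronger inhibition and higher numbers for weaker inhibition), compound 1 gives 200 nM, compound 2 gives 708 nM and compound 3 gives 490 nM, the second highest of the three numbers. The moves a 3.5-fold higher number from compound 1 to compound 2 (0.55 log units; beyond the scatter) and a 2.5-fold higher number from compound 1 to compound 3 (0.39 log units; beyond the scatter) show that replacing methyl by either alkoxy group weakened inhibition modestly, while a 1.4-fold lower number from compound 2 to compound 3 (0.16 log units; within the scatter) stayed within the scatter. Compound 4 `CSc1ccccc1CNc1ncnn1-c1cccc(Cl)c1Cl` carries the change (methylsulfanyl in place of ethoxy on an aromatic carbon). Going by the values given here, no measured step involves a sulfur-bearing group, so the expectation rests on these three numbers alone, and the step of a 1.4-fold lower number from compound 3 to compound 4 (0.15 log units; within the scatter) is estimated to stay within the scatter. Compound 4 is therefore expected to give about 350 nM, between 150 nM and 900 nM.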

Compound 4, half-maximal inhibitory concentration: 288 nM
The estimate for compound 4 lay 1.2-fold (0.08 log units) above the measured number; low and high end bracket the measured number.
By their numbers in this assay, from the lowest: compounds 1, 4, 3 and 2 (each within the scatter of the next, the first and the last beyond it).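

Changing the oxygen of compound 2 to the sulfur of compound 4 matters at this position: a 2.5-fold lower number from compound 2 to compound 4 (0.39 log units; beyond the scatter). The other two steps, a 1.7-fold lower number from compound 3 to compound 4 (0.23 log units; within the scatter) and a 1.4-fold higher number from compound 1 to compound 4 (0.16 log units; within the scatter), both stay within the scatter, so methylsulfanyl, unlike methoxy, cannot be told apart from methyl, and a group attached through a non-carbon atom need not sit beyond methyl. Nothing available explains the difference between sulfur and oxygen here.

Still open, going by these compounds, is how a chlorine, an amine or a longer chain such as propylsulfanyl would read at this place.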